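Trading a hexyloxy chain for isopentyloxy

The source may hold more compounds than are shown below. What is called first, only, known or untested is meant among the compounds shown, and "the series" means these compounds.

Compound 1: `CCC1CCN(c2nc(C(C)(C)C)ccc2CNC(=O)C(C)c2ccc(NS(C)(=O)=O)c(F)c2)CC1` — 0.1 nM
Compound 2: `CCCCCCOc1nc(C(C)(C)C)ccc1CNC(=O)C(C)c1ccc(NS(C)(=O)=O)c(F)c1` — 2.7 nM

Among the measured compounds shown here, in an assay on cells for antagonist activity at transient receptor potential cation channel subfamily V member 1 (Homo sapiens), read by FLIPR and calcium flux, with a stated time of 6 min (on this read-out higher numbers stand for weaker inhibition and lower numbers for stronger inhibition), compound 2 holds the higher of the two numbers; its only neighbour is compound 1, separated by a 27-fold higher number from compound 1 to compound 2 (1.43 log units; beyond the scatter). Compound 3 `CC(C)CCOc1nc(C(C)(C)C)ccc1CNC(=O)C(C)c1ccc(NS(C)(=O)=O)c(F)c1` differs from compound 2 by isopropyl in place of butyl on a saturated chain carbon, two bonds along the chain from an oxygen on an aromatic ring. For the measured compounds named here, no measured step bears on this change: the single step measured replaces the whole group on the aromatic carbon rather than reshaping the chain. With nothing to lean on, compound 3 is expected to stay close to compound 2, a step of a 1.1-fold higher number from compound 2 to compound 3 (0.05 log units; within the scatter) within the scatter. The estimate for compound 3 is 3 nM, between 1 nM and 9 nM.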

Compound 3, inhibition constant: 0.8 nM
Compound 3: the middle estimate sits 3.8-fold (0.57 log units) above what was measured; measured number below the stated range.
By their numbers in this assay, from the lowest: compound 1; then compound 3; then compound 2.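

In this assay, the end of the oxygen-linked chain matters on its own: with the rest of the chain and the core unchanged, isopropyl in place of butyl gives a 3.4-fold lower number from compound 2 to compound 3 (0.53 log units; beyond the scatter). This change does not close the gap to the piperidine, with isopentyloxy in place of 4-ethylpiperidin-1-yl giving an 8.0-fold higher number from compound 1 to compound 3 (0.90 log units; beyond the scatter). Nothing available explains either step.

Isopropyl differs from butyl both in branching and in holding one carbon fewer, so the compounds shown do not separate these two changes. Going by these compounds, how a cyclopropyl or an amine would read in that place also remains open.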